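Rat Plasma Half-Life Across Three Ester Variants

A few compounds are considered here, and "the series" means these few. Any claim that something is new, unique, unknown or untested is made for them only; others in the source may bear on it.

Three compounds share one core and differ only in the group on a carbonyl carbon. Compound 1 `CCCCC(=O)O[C@@H]1CO[C@H]2[C@@H]1OC[C@@H]2OC(=O)c1ccccc1OC(C)=O` carries butyl there; in an ADME assay on a cell-free system (plasma, Homo sapiens) for metabolic stability, with Plasma (Rattus norvegicus) as the target, read by HPLC, at pH 7.4 (a lower number here means that the compound disappears faster, a higher number that the compound lasts longer), compound 1 gives 0.0117 h. In this assay compound 2 `CC(=O)Oc1ccccc1C(=O)O[C@H]1CO[C@H]2[C@@H]1OC[C@H]2OC(=O)c1ccccc1C` gives 0.0138 h, and compound 3 `CC(=O)Oc1ccccc1C(=O)O[C@H]1CO[C@H]2[C@@H]1OC[C@H]2OC(=O)c1cc(C)nc(Cl)c1` gives 0.0193 h. Compound 2 stands second highest of the three numbers, with a 1.2-fold higher number from compound 1 to compound 2 (0.07 log units; within the scatter) and a 1.4-fold higher number from compound 2 to compound 3 (0.15 log units; within the scatter) both within the scatter. Compound 4 `CC(=O)Oc1ccccc1C(=O)O[C@H]1CO[C@H]2[C@@H]1OC[C@H]2OC(=O)c1ccc(CO[N+](=O)[O-])cc1` differs from compound 2 by 4-((nitrooxy)methyl)phenyl in place of 2-methylphenyl on a carbonyl carbon. Because a 1.2-fold higher number from compound 1 to compound 2 (0.07 log units; within the scatter), a 1.6-fold higher number from compound 1 to compound 3 (0.22 log units; within the scatter) and a 1.4-fold higher number from compound 2 to compound 3 (0.15 log units; within the scatter) all stayed within the scatter, no step beyond the scatter is expected for compound 4, i.e. an expected 1.1-fold higher number from compound 2 to compound 4 (0.04 log units; within the scatter). Compound 4 is therefore estimated at 0.015 h, within a range from 0.007 h to 0.035 h.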

Compound 4, half-life: 0.04 h
Compound 4: the middle estimate sits 2.7-fold (0.43 log units) below what was measured; measured number above the stated range.
By their numbers in this assay, from the lowest: compounds 1, 2 and 3 (each within the scatter of the next); then compound 4.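

In this assay the group on a carbonyl carbon turns out to be able to move the number beyond the scatter, which no exchange among butyl, 2-methylphenyl and 2-chloro-6-methylpyridin-4-yl had done. Bringing in 4-((nitrooxy)methyl)phenyl gives a 2.9-fold higher number from compound 2 to compound 4 (0.46 log units; beyond the scatter) and a 2.1-fold higher number from compound 3 to compound 4 (0.32 log units; beyond the scatter) and also a 3.4-fold higher number from compound 1 to compound 4 (0.53 log units; beyond the scatter) as the largest step in the set. Nothing measured here accounts for this rise. The compounds shown leave open whether the step belongs to the nitrooxy part or to the rest of the group. From the compounds shown here alone, how a hydroxymethyl, an amine or a carboxylic acid at this place would read also remains open.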